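Acid to methylamide on the shared core

The source may report more compounds than this note shows. Statements on the series, on what has been measured and on what is new or still open speak of the compounds shown alone.

Compound 1 `C=C(C(=O)O)C1OC(=O)[C@H]2[C@H]1[C@@H](C(C)C)CC[C@@]2(O)CI` in a functional assay on HCT-116 cells (Homo sapiens) for inhibition, with a stated time of 72 h (a higher number here means a weaker inhibitor, a lower number a stronger inhibitor), gives > 10000 nM, which is a limit of the assay and not a number. Among the measured compounds shown here, compound 2 `CC(C)[C@H]1CC[C@@]2(CO2)[C@H]2C(=O)OCC(C(=O)O)=C[C@H]12` in this assay gives 210 nM; this is the only number in the set, so compound 2 has no measured neighbour to rank against. For the measured compounds named here, the value of compound 1 is a limit, and the only evidence on hand is the limit of > 10000 nM in this assay, at which 1 of the 2 values shown sits. Compound 3 `CNC(=O)C1=C[C@@H]2[C@@H](C(C)C)CC[C@@]3(CO3)[C@H]2C(=O)OC1` is not yet measured and differs from compound 2 by methylamino in place of hydroxy on a carbonyl carbon, a change on a carbonyl carbon whose other neighbour is a double-bonded ring carbon. Going by the values given here, no step between measured compounds is known, so no size of effect can be read from the data. The step of a 1.4-fold higher number from compound 2 to compound 3 (0.15 log units; within the scatter) is expected to stay within the usual scatter, with the wide range reflecting the lack of a comparable measured pair. Compound 3 is accordingly estimated at 300 nM, between 70 nM and 1500 nM.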

Compound 3, half-maximal inhibitory concentration: 7100 nM
Compound 3: middle estimate off by 24-fold (1.37 log units), on the low side; the measured number lies above the stated range.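

In this assay, methylamino in place of hydroxy on a carbonyl carbon whose other neighbour is a double-bonded ring carbon gives a 34-fold higher number from compound 2 to compound 3 (1.53 log units; beyond the scatter), a large step beyond the scatter. This first measured step shows that inhibition at this position is sensitive to the change from carboxy to methylcarbamoyl, even though hydroxy and methylamino have the same computed count of hydrogen-bond donors. The data on hand give no cause for this step.

One step cannot show whether the loss follows from the methyl group or from replacing the carboxy group with an amide; a primary amide and a methyl ester on the same carbonyl carbon would bear on that question. On these data alone, whether a tetrazole could stand in for the carboxy group also remains open.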